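Piperidine Bearing Acetyl Replaces Methyl on the Pyrazole Nitrogen

A few compounds are considered here, and "the series" means these few. Any claim that something is new, unique, unknown or untested is made for them only; others in the source may bear on it.

Compound 2 `C=CC(=O)Nc1cccc(-n2c(-c3nc(-c4cnn(C)c4)cnc3N)nc3ccccc32)c1` gives the lowest number of the three measured compounds in an ADME assay on liver for metabolic stability, with Liver microsome (Homo sapiens) as the target, using microsomes (a higher number here means faster removal of the compound, a lower number slower removal), at 24 mL.min-1.g-1. Compound 1 `C=CC(=O)Nc1cccc(-n2c(-c3nc(-c4cnn(C5CCN(C)CC5)c4)cnc3N)nc3ccccc32)c1` gives 120 mL.min-1.g-1, and compound 3 `C=CC(=O)Nc1cccc(-n2c(-c3nc(-c4cnn(C5CCN(CC)CC5)c4)cnc3N)nc3ccccc32)c1` gives 197 mL.min-1.g-1. Compound 4 `C=CC(=O)Nc1cccc(-n2c(-c3nc(-c4cnn(C5CCN(C(C)=O)CC5)c4)cnc3N)nc3ccccc32)c1` differs from compound 2 by 1-acetylpiperidin-4-yl in place of methyl on an aromatic nitrogen. Within the data shown here, two measured steps bear on this change: a 5.0-fold lower number from compound 1 to compound 2 (0.70 log units; beyond the scatter), and an 8.2-fold higher number from compound 2 to compound 3 (0.91 log units; beyond the scatter). Both show a piperidin-4-yl group on that aromatic nitrogen, whether carrying methyl or ethyl, going with a higher number than methyl alone. Going by these compounds, because an 8.2-fold higher number from compound 2 to compound 3 (0.91 log units; beyond the scatter) and a 5.0-fold lower number from compound 1 to compound 2 (0.70 log units; beyond the scatter) point the same way, compound 4 is expected to give a higher number as well, though an acetyl group on the piperidine is untested here, so a smaller step is estimated: a 2.9-fold higher number from compound 2 to compound 4 (0.46 log units; beyond the scatter). Compound 4 is therefore estimated at 70 mL.min-1.g-1, with a range from 30 mL.min-1.g-1 to 160 mL.min-1.g-1.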

Compound 4, intrinsic clearance in microsomes: > 300 mL.min-1.g-1
Compound 4: only a limit was reported; the forecaster's own chance of this, stated with the estimate: 0%; middle value at least 4.2-fold (0.63 log units) away from the limit.
By their numbers in this assay, from the lowest: compound 2; then compounds 1 and 3 (each within the scatter of the next). At a limit, above all of these: compound 4.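

In this assay, compound 4 gives a limit rather than a number: the limit of > 300 mL.min-1.g-1 in this assay, at which 1 of the 4 values shown sits. Even as a floor, the move from methyl to 1-acetylpiperidin-4-yl on the aromatic nitrogen is an at least 12-fold higher number from compound 2 to compound 4 (1.09 log units; beyond the scatter), and acetyl on the piperidine nitrogen does not return the number towards that of compound 2, with an at least 2.5-fold higher number from compound 1 to compound 4 (0.39 log units; beyond the scatter). Acetyl in place of ethyl gives an at least 1.5-fold higher number from compound 3 to compound 4 (0.18 log units; that floor lies within the scatter), which does not separate the two. Going by these compounds, how far compound 4 lies beyond its limit stays open. Also open, on these data alone, is whether an unsubstituted piperidin-4-yl, or a short chain ending in a carboxylic acid, on that aromatic nitrogen would give a number nearer that of compound 2.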